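The source may hold more compounds than are shown below. What is called first, only, known or untested is meant among the compounds shown, and "the series" means these compounds.

Working notes on the series. In a functional assay on PC-3 cells (Homo sapiens) for cytotoxicity, read by WST assay, with a stated time of 3 days (a higher number here means a weaker inhibitor, a lower number a stronger inhibitor), compound 1 `CCCn1ccnc1/C=C/C(=O)/C=C/c1coc2ccccc2c1=O` gives 2400 nM, level within the scatter with compound 2 `CCCCn1ccnc1/C=C/C(=O)/C=C/c1coc2ccccc2c1=O` at 2000 nM and compound 3 `CCCCCn1ccnc1/C=C/C(=O)/C=C/c1coc2ccccc2c1=O` at 2100 nM. Compound 4 `CCC(C)n1ccnc1/C=C/C(=O)/C=C/c1coc2ccccc2c1=O` differs from compound 1 by methyl in place of hydrogen on a saturated chain carbon bound to an aromatic nitrogen and a saturated chain carbon, or propyl to sec-butyl. The nearest measured steps are a 1.2-fold lower number from compound 1 to compound 2 (0.08 log units; within the scatter), a 1.1-fold lower number from compound 1 to compound 3 (0.06 log units; within the scatter) and a 1.1-fold higher number from compound 2 to compound 3 (0.02 log units; within the scatter), all within the scatter. Going by the values given here, these steps lie further along the chain, and no measured step touches this carbon. No step beyond the scatter is therefore expected in this assay. The expected step is a 1.1-fold lower number from compound 1 to compound 4 (0.04 log units; within the scatter). Compound 4 is estimated at 2200 nM, with an expected range of 1200 nM to 4000 nM.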

Compound 4, half-maximal inhibitory concentration: 1800 nM
Estimate against measurement, compound 4: 1.2-fold (0.09 log units) above, and the stated range covers the measured number.
By their numbers in this assay, from the lowest: compounds 4, 2, 3 and 1 (each within the scatter of the next).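

In this assay, going by these compounds alone, methyl in place of hydrogen on a saturated chain carbon bound to an aromatic nitrogen and a saturated chain carbon, a carbon no earlier step touched, stays within the scatter (a 1.3-fold lower number from compound 1 to compound 4 (0.12 log units; within the scatter)). Sec-butyl also stands level with the unbranched chains (a 1.1-fold lower number from compound 2 to compound 4 (0.05 log units; within the scatter); a 1.2-fold lower number from compound 3 to compound 4 (0.07 log units; within the scatter)). The same change reads alike at this carbon and further along the chain: (the same change on two cores in this assay, a 1.1-fold higher number (0.02 log units; within the scatter) from compound 2 to compound 3 and a 1.3-fold lower number (0.12 log units; within the scatter) from compound 1 to compound 4, 1.4-fold (0.15 log units) apart, within the scatter of two such steps).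

Still open, on these data alone, is whether any group on this aromatic nitrogen moves the number beyond the scatter. A tert-butyl, a benzyl or a chain ending in an amine would test this.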